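Methyl moved around the ring, every reading at the limit

The source may report more compounds than this note shows. Statements on the series, on what has been measured and on what is new or still open speak of the compounds shown alone.

Compound 3 `COc1cccc(/C=C/C(=O)c2sc(Nc3ccccc3C)nc2C)c1` shares its core with compound 1 `COc1cccc(/C=C/C(=O)c2sc(Nc3cccc(C)c3)nc2C)c1` and compound 2 `Cc1ccc(Nc2nc(C)c(C(=O)/C=C/c3ccc(Cl)cc3)s2)cc1`. In a functional assay on NCI-H460 cells (Homo sapiens) for cytotoxicity, read by MTT assay (a higher number here means a weaker inhibitor, a lower number a stronger inhibitor), compound 1 gives only a limit, > 25000 nM. Compound 2 also gives a limit, > 25000 nM. Compound 3 likewise gives a limit, > 25000 nM. All three readings therefore sit at the limit of > 25000 nM in this assay, at which 3 of the 3 values shown sit, and the step that the two limits leave unreadable from compound 1 to compound 3 cannot be read. Compound 4 `COc1cccc(/C=C/C(=O)c2sc(Nc3ccc(C)cc3)nc2C)c1` differs from compound 3 by 4-methylphenyl in place of 2-methylphenyl on a nitrogen on an aromatic ring. Going by the values given here, the only measured step that touches this ring, a step that the two limits leave unreadable from compound 1 to compound 3, gives no readable size, so no shift beyond the scatter is expected from moving the methyl again. Compound 4 is therefore expected to give a limit rather than a number, an estimated 30000 nM with a range from 12000 nM to 100000 nM. The expected step that the limit leaves unreadable from compound 3 to compound 4 is thus essentially none.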

Compound 4, half-maximal inhibitory concentration: > 25000 nM
Compound 4: no number, only a limit (the forecaster's own chance of this, stated with the estimate: 85%); the middle value does not contradict the limit.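

The steps to compound 4 from compound 1, compound 2 and compound 3 cannot be read, because each reading is only a limit: the limit of > 25000 nM in this assay, at which 4 of the 4 values shown sit.

Which change to the shared core, if any, would give a true number in this assay stays open.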